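Swapping a chloropyridinyl amide for a methylsulfonylphenyl isomer

The source may report more compounds than this note shows. Statements on the series, on what has been measured and on what is new or still open speak of the compounds shown alone.

Compound 1, `CS(=O)(=O)c1ccc(C(=O)Nc2ccc(Cl)c(-c3nnc4c(Cl)cccn34)c2)cc1`: in a functional assay on MCF7 cells (Homo sapiens) for antiproliferative activity, read by MTT assay, with a stated time of 72 h (a lower number here means a stronger inhibitor, a higher number a weaker inhibitor), compound 1 gives 94200 nM.
Compound 2, `O=C(Nc1ccc(Cl)c(-c2nnc3c(Cl)cccn23)c1)c1cccnc1Cl`: in this assay compound 2 reaches only the limit of > 100000 nM, a limit rather than a number.

Compound 2 thus stands at the edge of what this assay reports, as the evidence notes: the limit of > 100000 nM in this assay, at which 1 of the 2 values shown sits. Going by the values given here, the one measured step that touches it runs from compound 1 to compound 2, where an at least 1.0-fold higher number from compound 1 to compound 2 (0.02 log units; that floor lies within the scatter), a step that lies within the scatter and ends at a limit.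

Compound 3, `CS(=O)(=O)c1cccc(C(=O)Nc2ccc(Cl)c(-c3nnc4c(Cl)cccn34)c2)c1`, is the next compound. Its change from compound 2 is 3-(methylsulfonyl)phenyl in place of 2-chloropyridin-3-yl on a carbonyl carbon. The measured step in the opposite direction, from the 4-(methylsulfonyl)phenyl of compound 1 to the 2-chloropyridin-3-yl of compound 2, was an at least 1.0-fold higher number from compound 1 to compound 2 (0.02 log units; that floor lies within the scatter), so returning to a methylsulfonyl phenyl, now at the 3-position, is expected to give no step beyond the scatter: a number no higher from compound 2 to compound 3 (the limit leaves the size open). Compound 3 is therefore estimated at 100000 nM in this assay, with a range from 40000 nM to 250000 nM, and a real chance that only a limit is reported.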

Compound 3, half-maximal inhibitory concentration: 88900 nM
The estimate for compound 3 lay 1.1-fold (0.05 log units) above the measured number, and the stated range covers the measured number.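

Moving the methylsulfonyl group on the phenyl ring, with 3-(methylsulfonyl)phenyl in place of 4-(methylsulfonyl)phenyl on the carbonyl carbon, gives a 1.1-fold lower number from compound 1 to compound 3 (0.03 log units; within the scatter), so in this assay the two isomers cannot be told apart and the position of this group on the ring makes no readable difference. Replacing the 2-chloropyridin-3-yl of the amide with the 3-(methylsulfonyl)phenyl gives an at least 1.1-fold lower number from compound 2 to compound 3 (0.05 log units; that floor lies within the scatter), and this floor shows no real change in either direction. Compound 2 remains a limit and not a number, which leaves the true size of that step open: the limit of > 100000 nM in this assay, at which 1 of the 3 values shown sits.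

The compounds shown keep the shared core and vary only the group on this carbonyl carbon, so they leave open whether any group in this place can move the number beyond the scatter of the two methylsulfonyl isomers. On these data alone, what a carboxylic acid or an amine on the phenyl ring in place of the methylsulfonyl group would give in this assay also stays open, as does any change to the core itself.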